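Alkoxy variation in a small aromatase inhibitor series

This account rests on a few compounds, and the source may have more. Where it says the series, first, only, none or still open, it means among the compounds named here.

Measured in an assay on SK-BR-3 cells for inhibition of Aromatase (Homo sapiens); a higher number here means a weaker inhibitor, a lower number a stronger inhibitor:
compound 1, `CS(=O)(=O)Nc1ccc([N+](=O)[O-])cc1OCC1CCCCC1`, gives 1210 nM
compound 2, `CS(=O)(=O)Nc1ccc([N+](=O)[O-])cc1OC1CCCC1`, gives 870 nM
compound 3, `CCCCCCOc1cc([N+](=O)[O-])ccc1NS(C)(=O)=O`, gives 2670 nM

Compound 3 carries the highest number of the three. The step of a 2.2-fold higher number from compound 1 to compound 3 (0.34 log units; beyond the scatter) and the step of a 3.1-fold higher number from compound 2 to compound 3 (0.49 log units; beyond the scatter) both lie beyond the scatter, whereas a 1.4-fold lower number from compound 1 to compound 2 (0.14 log units; within the scatter) does not, so the two ring-bearing ethers sit together and compound 3 stands apart from them, at the weak end of the set.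

Compound 4, `COc1cc([N+](=O)[O-])ccc1NS(C)(=O)=O`, is not yet measured. The change from compound 3 is hydrogen in place of pentyl on a saturated chain carbon bound to an oxygen on an aromatic ring, which leaves a methoxy group where hexyloxy stood. For the measured compounds named here, no measured step removes a chain in this way; the steps that bear on it only exchange one alkoxy group for another of comparable size, and both a 2.2-fold higher number from compound 1 to compound 3 (0.34 log units; beyond the scatter) and a 3.1-fold higher number from compound 2 to compound 3 (0.49 log units; beyond the scatter) moved the number up on going to the open hexyl chain. Nothing in the set shows what a much shorter chain does. The step away from compound 3 is expected to move the number further up rather than down, by a modest amount, a 1.9-fold higher number from compound 3 to compound 4 (0.27 log units; within the scatter). Compound 4 is therefore expected to give about 5000 nM in this assay, with a likely range from 1500 nM to 20000 nM, the wide span reflecting the absence of any comparable step.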

Compound 4, half-maximal inhibitory concentration: > 25000 nM
Compound 4 was reported as a limit (the forecaster's own chance of this, stated with the estimate: 20%); middle value at least 5.0-fold (0.69 log units) from the limit.
By their numbers in this assay, from the lowest: compounds 2 and 1 (each within the scatter of the next); then compound 3. At a limit, above all of these: compound 4.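

In this assay compound 4 is reported only as a limit of the assay and not as a number: the limit of > 25000 nM in this assay, at which 1 of the 4 values shown sits. Exchanges among the larger groups on the oxygen had produced only modest steps, whereas the move to methoxy gives an at least 9.3-fold higher number from compound 3 to compound 4 (0.97 log units; beyond the scatter), with an at least 28-fold higher number from compound 2 to compound 4 (1.45 log units; beyond the scatter) and an at least 20-fold higher number from compound 1 to compound 4 (1.31 log units; beyond the scatter) for the two ring-bearing ethers, so the two large steps are the first in the series and the true size of all three remains bounded only from one side. This position therefore does more than accept interchangeable alkoxy groups: hexyloxy, the cyclopentyl ether and the cyclohexylmethyl ether all give measured numbers on the shared core, while methoxy, the only small group shown, gives a limit, and no compound shown goes against this.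

The compounds shown leave open where between methoxy and hexyloxy the number falls into the measurable range, which ethoxy, propoxy or butoxy would locate. They also leave open whether a chain longer than hexyl, or a hydroxyl or an amine at the end of the hexyl chain, would keep the number in that range.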